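The source may hold more compounds than are shown below. What is called first, only, known or untested is meant among the compounds shown, and "the series" means these compounds.

Measured so far in an ADME assay on Vero 76 cells (Chlorocebus sabaeus) for cytotoxicity, read by MTT assay, with a stated time of 96 h; on this read-out lower numbers stand for higher toxicity in this test and higher numbers for lower toxicity in this test:
- compound 1 `NS(=O)(=O)c1ccc(N2N=C(c3ccc(Oc4ccccc4)cc3)CC2c2cccc(F)c2)cc1`: 28000 nM
- compound 2 `Cc1ccc(C2CC(c3ccc(Oc4ccccc4)cc3)=NN2c2ccc(S(N)(=O)=O)cc2)cc1`: 86000 nM

Of these two numbers, compound 2 stands highest at 86000 nM, and compound 1 lies lower at 28000 nM. Compound 3 `NS(=O)(=O)c1ccc(N2N=C(c3ccc(Oc4ccccc4)cc3)CC2c2ccccc2Cl)cc1` departs from compound 2 in one place, with 2-chlorophenyl in place of 4-methylphenyl on a saturated ring carbon, next to the ring nitrogen (2-chlorophenyl in place of 4-methylphenyl on a saturated ring carbon). For the measured compounds named here, only one measured step bears on this change: a 3.1-fold higher number from compound 1 to compound 2 (0.49 log units; beyond the scatter). It is modest, lies beyond the scatter and involves the same ring carbon, where 4-methylphenyl takes the place of 3-fluorophenyl. Going by the values given here, no measured compound carries 2-chlorophenyl, so the comparison is indirect and rests on a single pair. Compound 3 shares with compound 1 a halogen on this phenyl, and losing 4-methylphenyl would reverse the measured step, so a modest step to a lower number is expected in this assay, of about the same size or smaller. For compound 3 the estimated value is 40000 nM, with an expected range from 15000 nM to 100000 nM. This estimate means an expected 2.2-fold lower number from compound 2 to compound 3 (0.33 log units; beyond the scatter).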

Compound 3, half-maximal cytotoxic concentration: 29000 nM
The estimate for compound 3 lay 1.4-fold (0.14 log units) above the measured number; low and high end bracket the measured number.
By their numbers in this assay, from the lowest: compounds 1 and 3 (each within the scatter of the next); then compound 2.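

In this assay, the step of a 3.0-fold lower number from compound 2 to compound 3 (0.47 log units; beyond the scatter) runs opposite to a 3.1-fold higher number from compound 1 to compound 2 (0.49 log units; beyond the scatter), while a 1.0-fold higher number from compound 1 to compound 3 (0.02 log units; within the scatter) places 2-chlorophenyl and 3-fluorophenyl together on this saturated ring carbon. Among the three compounds shown, therefore, the two halogen-bearing phenyl groups, with different halogens at different ring positions, give numbers within the scatter of each other, and compound 2, with 4-methylphenyl, stands apart from both, with no compound here going against this. Nothing shown gives a reason for this grouping of the three values.

The compounds shown leave open whether the higher number of compound 2 goes with the methyl group itself or with substitution at the 4-position of the phenyl ring, since each step changes the group and its ring position together; 4-chlorophenyl and 2-methylphenyl would separate these two readings. They also leave open where unsubstituted phenyl or a phenyl bearing an amine or a carboxylic acid would fall on this ring carbon, and whether the same grouping would hold on a different core.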